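Amide ring substitution in a pyrazole carboxamide series

This account rests on a few compounds, and the source may have more. Where it says the series, first, only, none or still open, it means among the compounds named here.

Measured so far:
compound 1 `CCC(=O)Nc1cccc(CN2CCC(NC(=O)c3n[nH]cc3NC(=O)c3c(Cl)cccc3Cl)CC2)c1` — > 1000 nM
compound 2 `CN(C)C/C=C/C(=O)Nc1cccc(S(=O)(=O)N2CCC(NC(=O)c3n[nH]cc3NC(=O)c3ccccc3)CC2)c1` — 1000 nM
compound 3 `C=CC(=O)Nc1cccc(S(=O)(=O)N2CCC(NC(=O)c3n[nH]cc3NC(=O)c3c(OC)cc(OC)cc3OC)CC2)c1` — > 1000 nM

Going by the values given here, in an assay on HEK293 cells for inhibition of cyclin-dependent kinase 14 (Homo sapiens), with a stated time of 4 h (on this read-out lower numbers stand for stronger inhibition and higher numbers for weaker inhibition), compound 2 gives 1000 nM, the only number among the three values shown. For compound 1 this assay reports only a limit, > 1000 nM. For compound 3 it likewise reports only a limit, > 1000 nM. Among the compounds with values here, two of the three results therefore sit at the limit of > 1000 nM in this assay, at which 2 of the 3 values shown sit, and no step between measured compounds is available to gauge what a change on the amide ring does.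

Compound 4 `COc1cccc(Cl)c1C(=O)Nc1c[nH]nc1C(=O)NC1CCN(S(=O)(=O)c2cccc(NC(=O)/C=C/CN(C)C)c2)CC1` is the next point. It differs from compound 2 in one place: 2-chloro-6-methoxyphenyl in place of phenyl on a carbonyl carbon. Nothing measured speaks for a gain from substitution on that ring, while compound 1 and compound 3, each substituted there, sit at the limit. The step from compound 2 to compound 4 is expected to be small or nil in this assay, if anything toward weaker inhibition, as a 1.3-fold higher number from compound 2 to compound 4 (0.11 log units; within the scatter) states. Compound 4 is estimated at 1300 nM, within 400 nM to 4000 nM.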

Compound 4, half-maximal inhibitory concentration: 50 nM
Compound 4: middle estimate off by 26-fold (1.41 log units), on the high side, outside the stated range (below it).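

In this assay the place on the carbonyl carbon proves responsive, with a 20-fold lower number from compound 2 to compound 4 (1.30 log units; beyond the scatter) on replacing phenyl with 2-chloro-6-methoxyphenyl. Going by these compounds alone, this is the first evidence that substitution on this ring can strengthen inhibition when the rest of the molecule is held fixed. Compound 1 and compound 3 also carry substituted rings but differ from compound 4 in other places too, so substitution alone does not settle the outcome, and neither gives a readable step: the limit of > 1000 nM in this assay, at which 2 of the 4 values shown sit.

Going by these compounds, the step changes chlorine and methoxy together, so the share of each remains open, and 2-chlorophenyl or 2-methoxyphenyl alone would separate them. Also open, on these data alone, is whether larger or charged groups on this ring, such as ethoxy or dimethylamino in place of methoxy, are tolerated.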